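A few compounds are considered here, and "the series" means these few. Any claim that something is new, unique, unknown or untested is made for them only; others in the source may bear on it.

In a functional assay on C8166 cells (Homo sapiens) for cytotoxicity, read by MTT assay (a higher number here means that more compound is tolerated, a lower number that less compound is tolerated), compound 1 `Cc1cc(S(N)(=O)=O)ccc1NC(=O)COc1ccc(Cl)cc1NC(=O)c1ccccc1[N+](=O)[O-]` gives 54800 nM while compound 2 `Cc1cc(S(N)(=O)=O)ccc1NC(=O)COc1ccc(Cl)cc1NC(=O)c1cccc([N+](=O)[O-])c1` gives 58800 nM and compound 3 `Cc1ccc(C)c(C(=O)Nc2cc(Cl)ccc2OCC(=O)Nc2ccc(S(N)(=O)=O)cc2C)c1` gives 79700 nM so compound 3 stands within the scatter of both others. Next is compound 4 `Cc1cc(C)cc(C(=O)Nc2cc(Cl)ccc2OCC(=O)Nc2ccc(S(N)(=O)=O)cc2C)c1` where the difference from compound 3 is 3,5-dimethylphenyl in place of 2,5-dimethylphenyl on a carbonyl carbon with 3,5-dimethylphenyl in place of 2,5-dimethylphenyl on a carbonyl carbon. Three measured changes at this carbonyl carbon bear on it: a 1.1-fold higher number from compound 1 to compound 2 (0.03 log units; within the scatter) and a 1.5-fold higher number from compound 1 to compound 3 (0.16 log units; within the scatter) and a 1.4-fold higher number from compound 2 to compound 3 (0.13 log units; within the scatter) all stay within the scatter. None of them moves a methyl group, so the precedent is indirect. No step beyond the scatter is therefore expected in this assay in either direction. The step is estimated as a 1.1-fold lower number from compound 3 to compound 4 (0.06 log units; within the scatter) and is expected to stay inside the scatter. Compound 4 is expected at 70000 nM with an estimated range from 40000 nM to 115000 nM as its span.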

Compound 4, half-maximal cytotoxic concentration: 36500 nM
The estimate for compound 4 lay 1.9-fold (0.28 log units) above the measured number; measured number outside the range, below it.
By their numbers in this assay, from the lowest: compounds 4, 1, 2 and 3 (each within the scatter of the next, the first and the last beyond it).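

In this assay, going by these compounds alone, the swap of 2,5-dimethylphenyl for 3,5-dimethylphenyl on the carbonyl carbon is the first change here to pass the scatter (a 2.2-fold lower number from compound 3 to compound 4 (0.34 log units; beyond the scatter)), although both groups have the same atoms. Compound 4 stays within the scatter of both nitrophenyl compounds (a 1.6-fold lower number from compound 2 to compound 4 (0.21 log units; within the scatter); a 1.5-fold lower number from compound 1 to compound 4 (0.18 log units; within the scatter)), so the order of the two dimethylphenyl compounds is the only separation this position gives. Nothing available explains the step. Still open, as far as these compounds go, is whether a single methyl group on the phenyl, as in 3-methylphenyl, would follow compound 4 or compound 3. From the compounds shown here alone, an amine or a carboxylic acid on that phenyl also remains untested in these data.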